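The source may hold more compounds than are shown below. What is called first, only, known or untested is meant among the compounds shown, and "the series" means these compounds.

Measured so far:
compound 1 `COc1ccc(-c2cc(/C=C/C(=O)c3ccc(N)cc3)[nH]n2)cc1` gives 22% in a functional assay on Hs-578T cells (Homo sapiens) for cytotoxicity, read by sulforhodamine B assay, with a stated time of 48 h, tested at 10 uM; a higher number here means a weaker effect of the compound at the concentration tested, a lower number a stronger effect;
compound 2 `COc1cc(-c2cc(/C=C/C(=O)c3ccc(N)cc3)[nH]n2)cc(OC)c1OC` gives 29%;
compound 3 `COc1cc(-c2cc(/C=C/C(=O)c3ccc(Cl)c(Cl)c3)[nH]n2)cc(OC)c1OC` gives 63%.

Among these three numbers compound 2 stands second highest: compound 1 lies within the scatter of it, while compound 3 sits well above it. Compound 4 `COc1ccc(C(=O)/C=C/c2cc(-c3cc(OC)c(OC)c(OC)c3)n[nH]2)cc1` differs from compound 2 in one place: methoxy in place of amino on an aromatic carbon. For the measured compounds named here, only one measured step touches the same 4-aminophenyl on the carbonyl carbon: a number 34 percentage points higher from compound 2 to compound 3 (beyond the scatter). That step swapped in 3,4-dichlorophenyl rather than a methoxy group, so it serves only as a rough guide. A rise in this assay toward a weaker effect, smaller than that one, is expected for compound 4: a number 16 percentage points higher from compound 2 to compound 4 (beyond the scatter). Compound 4 is therefore estimated at 45%, within 25% to 70%.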

Compound 4, a percentage reported as activity, at one concentration (the size of the read-out at that concentration, not a potency): 13%
Compound 4: middle estimate off by 32 percentage points, on the high side; measured number below the stated range.
By their numbers in this assay, from the lowest: compounds 4, 1 and 2 (each within the scatter of the next, the first and the last beyond it); then compound 3.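

In this assay, the group on the carbonyl carbon can push the number down as well as up: methoxy in place of amino gives a number 16 percentage points lower from compound 2 to compound 4 (beyond the scatter), a stronger effect, whereas the earlier change here only raised it. This one position also spans a wide range, with a number 50 percentage points lower from compound 3 to compound 4 (beyond the scatter). No measurement at hand gives a reason for these shifts.

From the compounds shown here alone, whether a hydroxy or ethoxy group on that aromatic carbon would lower the number further remains open. So does whether methoxy in place of amino would bring a similar drop on the core of compound 1.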